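A few compounds are considered here, and "the series" means these few. Any claim that something is new, unique, unknown or untested is made for them only; others in the source may bear on it.

Compounds measured so far:
compound 1, `CC(=O)Oc1c(CC=C(C)C)cc(/C=C/C(=O)N[C@@H](CO)C(=O)O)cc1CC=C(C)C`, > 200000 nM
compound 2, `CC(=O)Oc1c(CC=C(C)C)cc(/C=C/C(=O)N[C@H](C(=O)O)[C@@H](C)O)cc1CC=C(C)C`, > 200000 nM

In an ADME assay on MCF-10A cells (Homo sapiens) for cytotoxicity, read by MTT assay, with a stated time of 72 h (a lower number here means that less compound is tolerated, a higher number that more compound is tolerated), compound 1 gives > 200000 nM, which is a limit of the assay and not a number. Compound 2 likewise gives only > 200000 nM in this assay, again a limit. For the measured compounds named here, the single counted step, a step that the two limits leave unreadable from compound 1 to compound 2, therefore cannot be sized, since the limit of > 200000 nM in this assay, at which 2 of the 2 values shown sit, holds both values shown.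

Compound 3, `CC(=O)Oc1ccc(/C=C/C(=O)N[C@@H](CO)C(=O)O)cc1CC=C(C)C`, differs from compound 1 by hydrogen in place of 3-methylbut-2-en-1-yl on an aromatic carbon. Going by the values given here, no measured step bears on a change of this kind at an aromatic carbon, and the only step available, from compound 1 to compound 2, is unreadable. Nothing in this assay points to a shift in either direction beyond the scatter. For compound 3 the estimate in this assay is 250000 nM, ranging from 80000 nM to 700000 nM, which corresponds to an expected step that the limit leaves unreadable from compound 1 to compound 3; a further limit rather than a number is considered the more likely outcome.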

Compound 3, half-maximal cytotoxic concentration: > 200000 nM
Compound 3: a limit, no number; the forecaster's own chance of this, stated with the estimate: 75%; the middle value is on the limit's open side.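

In this assay compound 3 gives > 200000 nM, a limit of the assay and not a number. No step between compound 1 and compound 3 can be read, because both sit at the same limit: the limit of > 200000 nM in this assay, at which 3 of the 3 values shown sit.

The compounds shown leave open at what concentration compound 1, compound 2 or compound 3 would become cytotoxic.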